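Methyl in place of hydrogen on compound 2

The source may report more compounds than this note shows. Statements on the series, on what has been measured and on what is new or still open speak of the compounds shown alone.

Two acids, compound 1 `C=C(CC)C(=O)c1ccc(OC(C)C(=O)O)cc1C` and compound 2 `C=C(CC)C(=O)c1ccc(OCC(=O)O)cc1Cl`, have been tested in a functional assay on HL-60 cells (Homo sapiens) for antiproliferative activity, with a stated time of 72 h; on this read-out higher numbers stand for weaker inhibition of growth and lower numbers for stronger inhibition of growth. Compound 1 gives > 60000 nM, which is a limit of the assay and not a number. Compound 2 gives > 60000 nM, also only a limit, and the expectation below rests on that limit. The record for compound 2 is therefore (the limit of > 60000 nM in this assay, at which 2 of the 2 values shown sit).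

Compound 3 `C=C(CC)C(=O)c1ccc(OC(C)C(=O)O)cc1Cl` differs from compound 2 by one change, methyl in place of hydrogen on a saturated chain carbon bound to a carbonyl carbon and an oxygen on an aromatic ring: carboxymethoxy becomes 1-carboxyethoxy. Among the compounds with values here, no measured pair shows what such a change does in this assay, so no shift beyond the usual scatter is expected, and compound 3 may well return only a limit too. The expected size of the step is a number no higher from compound 2 to compound 3 (the limit leaves the size open). For compound 3 the estimated value is 60000 nM, within an expected range of 25000 nM to 120000 nM.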

Compound 3, concentration for 50% growth inhibition: > 60000 nM
Compound 3: a limit, no number; the forecaster's own chance of this, stated with the estimate: 85%; the middle value lies on the limit itself.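

Compound 3 gives > 60000 nM in this assay, which is a limit of the assay and not a number, so its steps from compound 2 and from compound 1 cannot be read. The compounds shown leave open whether methyl in place of hydrogen, or chloro in place of methyl, changes growth inhibition at all.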